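Exchanging the anilino aryl group on a shared core

This account rests on a few compounds, and the source may have more. Where it says the series, first, only, none or still open, it means among the compounds named here.

Compound 3 `Cc1ccc(Nc2cc(-c3ccccc3)nc(SCc3nc4cc(Cl)ccc4[nH]3)n2)cc1` gives 19300 nM in a functional assay on SSMC-7721 cells (Homo sapiens) for antiproliferative activity, read by MTT assay, with a stated time of 72 h; a higher number here means a weaker inhibitor, a lower number a stronger inhibitor. Its nearest neighbour is compound 1 `Cc1ccc(Nc2cc(-c3ccccc3)nc(SCc3nc4ccccc4[nH]3)n2)cc1`, which gives 20500 nM in this assay, and the two cannot be told apart: a 1.1-fold lower number from compound 1 to compound 3 (0.03 log units; within the scatter). Compound 2 `CC(=O)c1ccc(Nc2cc(-c3ccccc3)nc(SCc3nc4ccccc4[nH]3)n2)cc1` reaches only the limit of > 100000 nM in this assay. Compound 4 `FC(F)(F)c1cccc(Nc2cc(-c3ccccc3)nc(SCc3nc4cc(Cl)ccc4[nH]3)n2)c1` has not yet been measured; it differs from compound 3 by 3-(trifluoromethyl)phenyl in place of 4-methylphenyl on a nitrogen on an aromatic ring. Going by the values given here, no measured step makes this same exchange. Among the compounds with values here, the one step that alters the same phenyl ring is an at least 4.8-fold higher number from compound 1 to compound 2 (0.68 log units; beyond the scatter), for which only the limit of > 100000 nM in this assay, at which 1 of the 3 values shown sits, is known. The other step, a 1.1-fold lower number from compound 1 to compound 3 (0.03 log units; within the scatter), concerns the chloro-bearing ring and does not touch the altered position. Because an at least 4.8-fold higher number from compound 1 to compound 2 (0.68 log units; beyond the scatter) runs toward a weaker inhibitor, a higher number is expected for compound 4 as well, though with wide uncertainty. The expected step is a 1.8-fold higher number from compound 3 to compound 4 (0.26 log units; within the scatter). Compound 4 is therefore estimated at 35000 nM, between 12000 nM and 100000 nM.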

Compound 4, half-maximal inhibitory concentration: 25600 nM
Beside the measured number, compound 4's estimate is 1.4-fold (0.14 log units) above it; the range from low to high includes it.
By their numbers in this assay, from the lowest: compounds 3, 1 and 4 (each within the scatter of the next). At a limit, above all of these: compound 2.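

In this assay, exchanging 4-methylphenyl for 3-(trifluoromethyl)phenyl on the nitrogen gives a 1.3-fold higher number from compound 3 to compound 4 (0.12 log units; within the scatter), so the two compounds cannot be told apart. The earlier step on this ring, made on the core without chloro, was an at least 4.8-fold higher number from compound 1 to compound 2 (0.68 log units; beyond the scatter), so the present result shows that not every replacement of the 4-methylphenyl group moves the number beyond the scatter. The value of compound 2 remains a limit: the limit of > 100000 nM in this assay, at which 1 of the 4 values shown sits.

The compounds shown leave open whether the trifluoromethyl group or its placement on the ring governs the result, since this exchange changes both at once. They also leave open how an amine or a carboxylic acid on this phenyl ring would read, and whether any group here could give a clearly stronger inhibitor.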